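This account rests on a few compounds, and the source may have more. Where it says the series, first, only, none or still open, it means among the compounds named here.

In a physicochemical assay for solubility, measured as kinetic solubility (a lower number here means a less soluble compound, a higher number a more soluble compound), compound 3 (`CCC/N=C1\S/C(=C\c2ccc(O)c(Cl)c2)C(=O)N1c1ccccc1OC`) reads 79000 nM and stands level with compound 1 (`CCC/N=C1\S/C(=C\c2ccc(O)c(Cl)c2)C(=O)N1C1CCS(=O)(=O)CC1`) at 75000 nM and with compound 2 (`CCC/N=C1\S/C(=C\c2ccc(O)c(Cl)c2)C(=O)N1C1CCOCC1`) at 70000 nM within the scatter. Compound 4 (`CCC/N=C1\S/C(=C\c2ccc(O)c(Cl)c2)C(=O)N1C1CC1`) carries cyclopropyl in place of 2-methoxyphenyl on an amide-type nitrogen in a ring. Three measured exchanges at that place bear on it, namely a 1.1-fold higher number from compound 1 to compound 3 (0.02 log units; within the scatter) and a 1.1-fold higher number from compound 2 to compound 3 (0.05 log units; within the scatter) and a 1.1-fold lower number from compound 1 to compound 2 (0.03 log units; within the scatter) (all within the scatter). None of them brings in cyclopropyl, so the expectation rests on these small steps alone, and no step beyond the scatter is expected in this assay for this change. The step expected is a 1.1-fold lower number from compound 3 to compound 4 (0.04 log units; within the scatter) on this reading. For compound 4 the expected value is 72000 nM (estimated range 40000 nM to 100000 nM).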

Compound 4, solubility: 79000 nM
Beside the measured number, compound 4's estimate is 1.1-fold (0.04 log units) below it; the range from low to high includes it.
By their numbers in this assay, from the lowest: compounds 2, 1, 3 and 4 (each within the scatter of the next).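

In this assay, the exchange for cyclopropyl gives no change at the digits printed from compound 3 to compound 4 (within the scatter), alongside a 1.1-fold higher number from compound 2 to compound 4 (0.05 log units; within the scatter) and a 1.1-fold higher number from compound 1 to compound 4 (0.02 log units; within the scatter). The earlier compounds had shown only six-membered rings at this place; a three-membered non-aromatic ring of carbon only now also stands level with them, so all four groups on the amide-type nitrogen in a ring lie within the scatter. No measurement offers an explanation for this flat result. From the compounds shown here alone, it remains open whether an amine, a carboxylic acid or a longer alkyl chain on that nitrogen would move the number beyond the scatter.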